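The source may report more compounds than this note shows. Statements on the series, on what has been measured and on what is new or still open speak of the compounds shown alone.

Compound 1, `CCC(C(=O)N1CCN(c2ccccc2F)CC1)N1C(=O)CCC1=O`, is the weakest of three compounds in a functional assay on the whole organism (strain Swiss) with Mus musculus as the target, in the maximal electroshock model, with a stated time of 0.5 h, at a dose of 100 mg/kg by the intraperitoneal route (a higher number here means a stronger effect of the compound at the dose given, a lower number a weaker effect), where compound 1 gives 0%. Its nearest neighbour in this assay is compound 3, `CCC(C(=O)N1CCN(c2ccccc2)CC1)N1C(=O)CCC1=O`, which gives 25%; the furthest is compound 2, `COCC(C(=O)N1CCN(c2cccc(C(F)(F)F)c2)CC1)N1C(=O)CCC1=O`, which gives 75%. Between compound 1 and compound 3 the only change is hydrogen in place of fluoro on an aromatic carbon, and this assay shows a number 25 percentage points higher from compound 1 to compound 3 (beyond the scatter).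

Compound 4, `CC(C(=O)N1CCN(c2ccccc2F)CC1)N1C(=O)CCC1=O`, has not yet been measured. It differs from compound 1 by hydrogen in place of methyl on a saturated chain carbon, two bonds along the chain from an amide-type nitrogen in a ring and a carbonyl carbon. Going by the values given here, no pair of measured compounds differs in this place alone: compound 2 carries a different group at the same chain carbon, but it also carries a different aromatic ring, so its value cannot be attributed to the chain. Among the compounds with values here, the one measured step concerns the aromatic ring, not the chain, and gives no guide here. In the absence of any step that bears on this change, compound 4 is expected to stay close to compound 1, with a step of no change at the digits printed from compound 1 to compound 4 (within the scatter), lying within the scatter. Compound 4 is therefore estimated to give 0% in this assay, with a range from 0% to 25%.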

Compound 4, a percentage reported as activity, at one dose (the size of the read-out at that dose, not a potency): 0%
For compound 4 middle estimate and measured number coincide at the digits printed; measured number inside the range.
By their numbers in this assay, from the lowest: compounds 1 and 4 (each within the scatter of the next); then compound 3; then compound 2.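

The chain carbon now has a step of its own, and in this assay hydrogen in place of methyl at this place, which can also be read as ethyl to methyl, gives no change at the digits printed from compound 1 to compound 4 (within the scatter). This step is read on the fluoro-bearing aromatic ring, where compound 1 gives 0% and compound 4 gives 0%, so both values lie at the bottom of the read-out: shortening the chain brings no effect into view, but a value at this level could not register any further loss, and the step cannot tell whether this chain carbon matters in a compound with a measurable effect. Nothing available offers an explanation for this result.

From the compounds shown here alone, it remains open whether the same change would leave the value undisturbed on the ring without fluoro of compound 3, which gives 25%, or on the trifluoromethyl-bearing ring of compound 2, which gives 75%. The compounds shown also leave open what a longer chain such as propyl, or a hydroxymethyl group, would do at this chain carbon, and how much of the value of compound 2 belongs to its chain rather than to its ring.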